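The source may hold more compounds than are shown below. What is called first, only, known or untested is meant among the compounds shown, and "the series" means these compounds.

Three compounds of this series have been run in a functional assay on A-375 cells (Homo sapiens) for inhibition, read by CCK-8 assay, with a stated time of 72 h, tested at 8 uM; a higher number here means more inhibition of growth at the concentration tested, a lower number less inhibition of growth. Compound 1 `Cc1ccc(SCc2ccc(/C=C/C(=O)Nc3ccccc3N)cc2)cc1` gives 31.2%. Compound 2 `Nc1ccccc1NC(=O)c1ccc(CSc2nccc(C(F)(F)F)n2)cc1` gives 80.1%. Compound 3 `Nc1ccccc1NC(=O)/C=C/c1ccc(CSc2ccc(F)cc2)cc1` gives 24.6%, the lowest of the three numbers; its nearest neighbour is compound 1, within the scatter, and the furthest is compound 2, beyond the scatter. Going by the values given here, the one single-point step so far, a number 6.6 percentage points lower from compound 1 to compound 3 (within the scatter), lies within the scatter.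

Compound 4 `Cc1cc(C)cc(SCc2ccc(/C=C/C(=O)Nc3ccccc3N)cc2)c1` has not yet been measured. Against compound 3 the change is 3,5-dimethylphenyl in place of 4-fluorophenyl on a sulfur. Among the compounds with values here, the only measured step that bears on this is the exchange of fluoro for methyl on the same ring, a number 6.6 percentage points lower from compound 1 to compound 3 (within the scatter), which stayed within the scatter; no measured pair tests the 3,5-dimethylphenyl itself, so the second methyl group is untried. On that basis no step beyond the scatter is expected in this assay, and the expected step is a number 5.4 percentage points higher from compound 3 to compound 4 (within the scatter). For compound 4 the estimate is 30%, with a range from 15% to 45%.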

Compound 4, percent growth inhibition at one concentration: 2.49%
The estimate for compound 4 lay 27.5 percentage points above the measured number; measured number outside the range, below it.
By their numbers in this assay, from the lowest: compound 4; then compounds 3 and 1 (each within the scatter of the next); then compound 2.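

On the sulfur, the aryl group can move the number beyond the scatter in this assay, which the exchange between 4-methylphenyl and 4-fluorophenyl did not show: 3,5-dimethylphenyl in place of 4-fluorophenyl gives a number 22.1 percentage points lower from compound 3 to compound 4 (beyond the scatter), and 3,5-dimethylphenyl in place of 4-methylphenyl gives a number 28.7 percentage points lower from compound 1 to compound 4 (beyond the scatter). Compound 1 already carries a methyl group on this ring, so the lower number goes with the 3,5-dimethylphenyl as a whole, not with the mere presence of a methyl group or the absence of fluorine. No measurement at hand accounts for the lower number of compound 4.

Going by these compounds, how a methoxy group or an amine on this ring, or a longer chain on the sulfur in place of the ring, would read in this assay stays open. Also open, on these data alone, is whether 3,5-dimethylphenyl would give a similar step on the core of compound 2.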